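Aryl carbamate on the oxygen of compound 1

This account rests on a few compounds, and the source may have more. Where it says the series, first, only, none or still open, it means among the compounds named here.

Measured compounds:
compound 1 `CC(C)=CCC1Cc2c(O)cc(=O)n(CCCO)c2CC1(C)C`: 0%
compound 2 `CC(C)=CCOc1cc(=O)n(CCCO)c2c1CC(CC=C(C)C)C(C)(C)C2`: 7.5%
compound 3 `CC(C)=CCC1Cc2c(OC(=O)Nc3ccc(F)cc3F)cc(=O)n(CCCO)c2CC1(C)C`: 0%

In a functional assay on PANC-1 cells (Homo sapiens) for inhibition, read by MTT assay, with a stated time of 24 h, tested at 10 uM (on this read-out lower numbers stand for less inhibition and higher numbers for more inhibition at the one concentration tested (going by the name of the read-out)), compound 1 gives 0%. It stands level with compound 3 at the digits reported, the two together being the lowest of the three numbers; its nearest neighbour is compound 3, with no change at the digits printed from compound 1 to compound 3 (within the scatter), and its furthest is compound 2, with a number 7.5 percentage points higher from compound 1 to compound 2 (within the scatter). Between the two substituted compounds the step is a number 7.5 percentage points lower from compound 2 to compound 3 (within the scatter). None of the three steps leaves the scatter, so the three numbers cannot be ordered.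

Compound 4 `CC(C)=CCC1Cc2c(OC(=O)Nc3ccc(F)c(Cl)c3)cc(=O)n(CCCO)c2CC1(C)C` is the next member. Relative to compound 1 the change is (3-chloro-4-fluorophenyl)carbamoyl in place of hydrogen on an oxygen on an aromatic ring. For the measured compounds named here, the step that bears on it most directly is the one from compound 1 to compound 3, where a (2,4-difluorophenyl)carbamoyl group entered at the same oxygen and the read-out moved by no change at the digits printed from compound 1 to compound 3 (within the scatter); the step from compound 2 to compound 3, a number 7.5 percentage points lower from compound 2 to compound 3 (within the scatter), points the same way. Both are within the scatter, so in this assay no step beyond the scatter is expected for compound 4.

For compound 4 the expected value in this assay is 2%, with a range from 0% to 12%. This estimate means a step of a number 2 percentage points higher from compound 1 to compound 4 (within the scatter).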

Compound 4, a percentage reported as inhibition, at one concentration (the size of the read-out at that concentration, not a potency): 0%
Compound 4: middle estimate off by 2 percentage points, on the high side, within the range that was stated.
By their numbers in this assay, from the lowest: compounds 1, 3, 4 and 2 (each within the scatter of the next).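

In this assay, the second aryl carbamate on this oxygen on an aromatic ring gives no change at the digits printed from compound 1 to compound 4 (within the scatter), so with compound 3 there are now two (arylamino)carbonyl-type carbamates that cannot be told apart from the free hydroxyl of compound 1 at the one concentration tested. For the compounds shown here, exchanging the aryl group on the amide-type nitrogen gives no change at the digits printed from compound 3 to compound 4 (within the scatter), which is the first direct comparison within the carbamates, and 3-chloro-4-fluorophenyl and 2,4-difluorophenyl are not separated by this assay. Against the ether, the change gives a number 7.5 percentage points lower from compound 2 to compound 4 (within the scatter), so the carbamate and the 3-methylbut-2-en-1-yl group on this oxygen also remain unordered, and all four compounds sit within the scatter of one another.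

Nothing available bears on why the number stays this flat at this oxygen. Open, from the compounds shown here alone, is whether a carbamoyl group carrying an amine or a carboxylic acid in place of the halogenated phenyl, or a longer chain on the ring nitrogen of the core of compound 1, would give a number beyond the scatter in this assay at all.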